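Fluoro to hydroxy on a chalcone: cytotoxicity outlook

The source may report more compounds than this note shows. Statements on the series, on what has been measured and on what is new or still open speak of the compounds shown alone.

Compound 1, with the structure `COc1cc(O)cc(O)c1C(=O)/C=C/c1ccc(F)cc1`, was tested in a toxicity assay on cells (Macrophage, Mus musculus, strain BALB/c) for cytotoxicity, read by MTT assay; on this read-out higher numbers stand for weaker inhibition and lower numbers for stronger inhibition. In this assay, among the compounds with values here, compound 1 gives 28800 nM, the only number available in the set. A second entry, compound 2 with the structure `C=CCOc1cc(OC)c(C(=O)/C=C/c2ccncc2)c(OCC=C)c1`, carries no result: for compound 2 this assay reports "not determined" (no result reported). Compound 1 therefore stands alone, with nothing to rank it against.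

Compound 3, with the structure `COc1cc(O)cc(O)c1C(=O)/C=C/c1ccc(O)cc1`, is the next compound to be measured. It differs from compound 1 by hydroxy in place of fluoro on an aromatic carbon, the change sitting on an aromatic carbon of a six-membered aromatic ring of carbon only. Within the data shown here, no measured pair in this set shows such a step, so its size cannot be read from data. He expects the step from compound 1 to compound 3 to be modest and, if anything, toward weaker inhibition, about a 1.3-fold higher number from compound 1 to compound 3 (0.12 log units; within the scatter). Compound 3 is accordingly estimated at 38000 nM, within a range from 15000 nM to 95000 nM.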

Compound 3, half-maximal inhibitory concentration: 21700 nM
For compound 3 the middle estimate is 1.8-fold (0.24 log units) above the measured one; the measured number falls inside the stated range.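

Only with the step between compound 1 and compound 3 does this position get a first reading: in this assay the change from 4-fluorophenyl to 4-hydroxyphenyl gives a 1.3-fold lower number from compound 1 to compound 3 (0.12 log units; within the scatter) and so leaves the two compounds indistinguishable. At this place, para to a large group, a hydroxy carrying one hydrogen-bond donor and one hydrogen-bond acceptor thus stands in for a fluoro carrying neither, with no change beyond the scatter on this read-out. No supporting evidence is available to explain this result.

Going by these compounds, it remains open whether an amine, a carboxylic acid or a longer chain at the same place would also stay within the scatter of compound 1. This single pair also cannot show whether the same swap would behave alike on a different core.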